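The compounds below may be only part of what the source reports. "The series", "measured", "known", "first", "only" and "open" are said of these compounds alone.

Compound 1 `COc1cc(Nc2ncnc3c(NC(=O)Nc4ccc(Cl)c(C(F)(F)F)c4)cccc23)cc(OC)c1`: > 20000 nM
Compound 2 `COc1cc(Nc2ncnc3c(NC(=O)Nc4ccc(F)cc4C(F)(F)F)cccc23)cc(OC)c1`: 2970 nM
Compound 3 `COc1cc(Nc2ncnc3c(NC(=O)Nc4ccc(Cl)cc4Cl)cccc23)cc(OC)c1`: 3060 nM

In a functional assay on RT-112 cells (Homo sapiens) for antiproliferative activity, read by MTT assay, with a stated time of 72 h (a lower number here means a stronger inhibitor of growth, a higher number a weaker inhibitor of growth), compound 3 gives 3060 nM, level with compound 2, since a 1.0-fold higher number from compound 2 to compound 3 (0.01 log units; within the scatter). Compound 1 reads > 20000 nM, which is a limit of the assay and not a number.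

Compound 4 `CCOC(=O)c1ccc(NC(=O)Nc2cccc3c(Nc4cc(OC)cc(OC)c4)ncnc23)cc1` keeps the shared core and changes one group: 4-(ethoxycarbonyl)phenyl in place of 2,4-dichlorophenyl on an amide-type nitrogen. Going by the values given here, three measured steps touch this same place. Two are large, an at least 6.7-fold lower number from compound 1 to compound 2 (0.82 log units; beyond the scatter) and an at least 6.5-fold lower number from compound 1 to compound 3 (0.81 log units; beyond the scatter), so a swap here can matter, and in either direction. Among the compounds with values here, none of the measured compounds carries the ester, so the direction is uncertain. A modest loss is expected, with a 2.0-fold higher number from compound 3 to compound 4 (0.29 log units; within the scatter) as the estimated step. The estimate for compound 4 is 6000 nM, with an expected range of 2000 nM to 20000 nM.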

Compound 4, concentration for 50% growth inhibition: 317 nM
Estimate against measurement, compound 4: 19-fold (1.28 log units) above; the measured number lies below the stated range.
By their numbers in this assay, from the lowest: compound 4; then compounds 2 and 3 (each within the scatter of the next). At a limit, above all of these: compound 1.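

Going by these compounds alone, at this place on the amide-type nitrogen, 4-(ethoxycarbonyl)phenyl gives the lowest number so far, with a 9.7-fold lower number from compound 3 to compound 4 (0.98 log units; beyond the scatter) and a 9.4-fold lower number from compound 2 to compound 4 (0.97 log units; beyond the scatter). So a swap here can also strengthen growth inhibition clearly, and a phenyl ring without halogen can do this. There is also an at least 63-fold lower number from compound 1 to compound 4 (1.79 log units; beyond the scatter), but that step rests on a limit: the limit of > 20000 nM in this assay, at which 1 of the 4 values shown sits.

From the compounds shown here alone, what stays open is whether the gain belongs to the ester itself. A carboxylic acid, a methyl ester or a nitrile in place of the ethoxycarbonyl group would be needed to tell.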